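Sulfanyl-linked methoxyphenyl variant of a potent sulfonamide

The source may report more compounds than this note shows. Statements on the series, on what has been measured and on what is new or still open speak of the compounds shown alone.

Among the compounds with values here, compound 1 `COc1cccc(Oc2c(NS(=O)(=O)c3ccc(C(C)(C)C)cc3)ncnc2OCCOc2ncc(Br)cn2)c1` holds the lowest number of the two compounds measured so far. In an assay on cells (Endothelial cell) for binding affinity to Endothelin-1 receptor (Sus scrofa) (on this read-out lower numbers stand for stronger inhibition and higher numbers for weaker inhibition), compound 1 gives 0.051 nM. Within the data shown here, the only other measured compound, compound 2 `COc1cccc(Oc2c(NS(=O)(=O)c3ccc(C(C)(C)C)cc3)ncnc2OCCOc2nccc(C)n2)c1`, gives 39.4 nM in this assay, and the single measured step, a 770-fold higher number from compound 1 to compound 2 (2.89 log units; beyond the scatter), arises from exchanging one pyrimidinyl group for another on the side chain, a part of the molecule untouched here.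

The new compound, compound 3 `COc1ccccc1Sc1c(NS(=O)(=O)c2ccc(C(C)(C)C)cc2)ncnc1OCCOc1ncc(Br)cn1`, differs from compound 1 at a different place: (2-methoxyphenyl)sulfanyl in place of 3-methoxyphenoxy on an aromatic carbon. The methoxyphenyl unit keeps its size, but its link to the shared core changes from an oxygen to a sulfur, and the methoxy moves from the 3- to the 2-position of that phenyl ring.

Among the measured compounds shown here, no measured step bears on this exchange, so the expectation rests only on the very low starting number of compound 1 and on the size of change a single substitution produced elsewhere. Compound 3 is therefore expected to give 0.4 nM, within a range from 0.05 nM to 3 nM. That estimate corresponds to an expected step of a 7.8-fold higher number from compound 1 to compound 3 (0.89 log units; beyond the scatter), a modest weakening that remains an expectation rather than a result.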

Compound 3, half-maximal inhibitory concentration: 0.018 nM
Compound 3: the middle estimate sits 22-fold (1.35 log units) above what was measured; the measured number lies below the stated range.
By their numbers in this assay, from the lowest: compound 3; then compound 1; then compound 2.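

In this assay, exchanging 3-methoxyphenoxy for (2-methoxyphenyl)sulfanyl gives a 2.8-fold lower number from compound 1 to compound 3 (0.45 log units; beyond the scatter), so this aromatic carbon, ortho to a 2-((5-bromopyrimidin-2-yl)oxy)ethoxy group, tolerates a sulfur link and a moved methoxy together, and the number falls further from an already very low start. The earlier step, a 770-fold higher number from compound 1 to compound 2 (2.89 log units; beyond the scatter), showed only how much the number can shift at the side chain, and the step at this second place is far smaller and runs the other way. Nothing available accounts for the lower number of compound 3.

The step joins two changes, the sulfur link and the move of the methoxy, and the compounds shown cannot separate them: neither (3-methoxyphenyl)sulfanyl nor 2-methoxyphenoxy stands among them. They also leave open whether a low number would survive with an amine as the link or an ethoxy in place of the methoxy, and how (2-methoxyphenyl)sulfanyl behaves alongside the 4-methylpyrimidin-2-yl side chain of compound 2.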